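A few compounds are considered here, and "the series" means these few. Any claim that something is new, unique, unknown or untested is made for them only; others in the source may bear on it.

Compound 1, `Cc1ccccc1-n1cc(CN2C(=O)C[C@@H]3CC[C@@]2(C)C3(C)C)nn1`, gives 150 nM in a functional assay on OVCAR-3 cells (Homo sapiens) for inhibition, read by MTT assay, with a stated time of 24 h; a higher number here means a weaker inhibitor, a lower number a stronger inhibitor.
Compound 2, `CC1(C)[C@H]2CC[C@]1(C)N(Cc1cn(-c3cccc(Br)c3)nn1)C(=O)C2`, gives 30 nM.
Compound 3, `CC1(C)[C@H]2CC[C@]1(C)N(Cc1cn(-c3ccccc3Cl)nn1)C(=O)C2`, gives 40 nM.

Compound 3 sits second highest of the three numbers; its nearest neighbour is compound 2, since a 1.3-fold higher number from compound 2 to compound 3 (0.12 log units; within the scatter) lies within the scatter, while a 3.8-fold lower number from compound 1 to compound 3 (0.57 log units; beyond the scatter) lies beyond it. Compound 4, `CC1(C)[C@H]2CC[C@]1(C)N(Cc1cn(-c3ccc(Br)cc3)nn1)C(=O)C2`, differs from compound 3 in one place: 4-bromophenyl in place of 2-chlorophenyl on an aromatic nitrogen. Within the data shown here, the steps that bear on this are a 5.0-fold lower number from compound 1 to compound 2 (0.70 log units; beyond the scatter) and a 1.3-fold higher number from compound 2 to compound 3 (0.12 log units; within the scatter), which together show that the phenyl bearing bromo and the phenyl bearing chloro gave similar numbers, both well below compound 1. Another bromo-bearing phenyl is therefore expected to give no step beyond the scatter, a 1.1-fold lower number from compound 3 to compound 4 (0.06 log units; within the scatter). Compound 4 is expected to give 35 nM, within a range from 15 nM to 90 nM.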

Compound 4, half-maximal inhibitory concentration: 140 nM
For compound 4 the middle estimate is 4.0-fold (0.60 log units) below the measured one; measured number above the stated range.
By their numbers in this assay, from the lowest: compounds 2 and 3 (each within the scatter of the next); then compounds 4 and 1 (each within the scatter of the next).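

With the same halogen on the phenyl, 4-bromophenyl in place of 3-bromophenyl gives a 4.7-fold higher number from compound 2 to compound 4 (0.67 log units; beyond the scatter), so where the bromo sits on this ring counts, not merely its presence. The change from 2-chlorophenyl also gives a step beyond the scatter, a 3.5-fold higher number from compound 3 to compound 4 (0.54 log units; beyond the scatter). The step from the 2-methylphenyl compound, a 1.1-fold lower number from compound 1 to compound 4 (0.03 log units; within the scatter), stays within the scatter, so a halogen on this phenyl does not by itself give a lower number.

Nothing available explains why the position of the bromo matters. Going by these compounds, how a phenyl bearing an amine or a carboxylic acid would behave here remains open.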